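A few compounds are considered here, and "the series" means these few. Any claim that something is new, unique, unknown or untested is made for them only; others in the source may bear on it.

Of the compounds shown here, three sharing one core have been measured in a functional assay on HCT-116 cells (Homo sapiens) for inhibition; on this read-out higher numbers stand for weaker inhibition and lower numbers for stronger inhibition. In this test, compound 1 `CCNC(=O)c1noc(-c2cc(C(C)C)c(O)cc2O)c1-c1cc(COCC(N)=O)no1` gives 97 nM, compound 2 `CCNC(=O)c1noc(-c2cc(C(C)C)c(O)cc2O)c1-c1cc(CN)no1` gives 84 nM and compound 3 `C=CNCc1cc(-c2c(C(=O)NCC)noc2-c2cc(C(C)C)c(O)cc2O)on1` gives 121 nM. Compound 3 thus stands within the usual scatter of repeated measurements of both other compounds, so the three numbers cannot be told apart.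

The next structure, compound 4 `CCNC(=O)c1noc(-c2cc(C(C)C)c(O)cc2O)c1-c1cc(CNC(=O)CC)no1`, keeps the core and changes one group: propanoyl in place of vinyl on an amine nitrogen. The nitrogen in question is attached to a saturated chain carbon.

Going by the values given here, three measured steps bear on this change. The closest is a 1.4-fold higher number from compound 2 to compound 3 (0.16 log units; within the scatter), made on this same nitrogen. The other two are a 1.2-fold lower number from compound 1 to compound 2 (0.06 log units; within the scatter) and a 1.2-fold higher number from compound 1 to compound 3 (0.10 log units; within the scatter), where a larger part of the group on the saturated chain carbon differs. Among the compounds with values here, none of these steps leaves the scatter, yet no measured compound carries propanoyl, so the estimate has to stay wide.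

In this assay, the expected step is a 1.2-fold lower number from compound 3 to compound 4 (0.08 log units; within the scatter), which means no change beyond the scatter is expected. The estimated value for compound 4 is 100 nM, with an expected range from 50 nM to 220 nM.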

Compound 4, half-maximal inhibitory concentration: 78 nM
Compound 4: middle estimate off by 1.3-fold (0.11 log units), on the high side; measured number inside the range.
By their numbers in this assay, from the lowest: compounds 4, 2, 1 and 3 (each within the scatter of the next).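

In this assay, putting propanoyl in place of vinyl on the amine nitrogen stays within the scatter (a 1.6-fold lower number from compound 3 to compound 4 (0.19 log units; within the scatter)), and so does putting propanoyl in place of hydrogen on the same nitrogen (a 1.1-fold lower number from compound 2 to compound 4 (0.03 log units; within the scatter)). Swapping carbamoylmethoxy for propanoylamino on the saturated chain carbon also stays within the scatter (a 1.2-fold lower number from compound 1 to compound 4 (0.09 log units; within the scatter)), so the amide of compound 4 joins the free amine of compound 2, the vinylamino group of compound 3 and the carbamoylmethoxy group of compound 1 in a set of four numbers that cannot be told apart. Nothing given here explains why these numbers stay so close.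

On these data alone, what remains open is how far this tolerance extends on the saturated chain carbon: a carboxylic acid, a longer acyl chain such as hexanoyl, or a benzoyl group on the amine nitrogen might move the number beyond the scatter or might not. These four compounds also say nothing about changes elsewhere on the shared core, such as replacing the isopropyl group or the ethyl group on the amide.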